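This account rests on a few compounds, and the source may have more. Where it says the series, first, only, none or still open, it means among the compounds named here.

Measured compounds:
Compound 1 `CCCCOc1ccc2c(Cl)ccnc2c1`: 2740 nM
Compound 2 `CCCCCCOc1ccc2c(Cl)ccnc2c1`: 2440 nM

Of the compounds shown here, two have been tested in a functional assay on HCT-116 cells (Homo sapiens) for cytotoxicity, read by MTT assay, with a stated time of 48 h; on this read-out lower numbers stand for stronger inhibition and higher numbers for weaker inhibition. Compound 1 gives 2740 nM, and compound 2 gives 2440 nM. For the measured compounds named here, compound 2 stands at the lower of the two numbers, but the only step between them, a 1.1-fold lower number from compound 1 to compound 2 (0.05 log units; within the scatter), lies within the scatter, so the two compounds are not separated on this read-out.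

Compound 3 `Clc1ccnc2cc(OCc3ccccc3)ccc12` has not been measured yet. It differs from compound 2 in one place: phenyl in place of pentyl on a saturated chain carbon bound to an oxygen on an aromatic ring. Going by the values given here, the single measured step bears on this only loosely, since a 1.1-fold lower number from compound 1 to compound 2 (0.05 log units; within the scatter) concerns lengthening of the chain by two carbons rather than exchange of a chain for an aromatic ring, and it produced no change beyond the scatter. Among the compounds with values here, nothing among the measured compounds shows what a phenyl at this place does. On that basis the step of a 1.2-fold lower number from compound 2 to compound 3 (0.09 log units; within the scatter) is expected to be small, in no clear direction. Compound 3 is therefore estimated at 2000 nM in this assay, with a range from 700 nM to 6000 nM.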

Compound 3, half-maximal inhibitory concentration: 2470 nM
For compound 3 the middle estimate is 1.2-fold (0.09 log units) below the measured one; low and high end bracket the measured number.
By their numbers in this assay, from the lowest: compounds 2, 3 and 1 (each within the scatter of the next).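

In this assay, phenyl in place of pentyl on a saturated chain carbon bound to an oxygen on an aromatic ring gives a 1.0-fold higher number from compound 2 to compound 3 (0.01 log units; within the scatter), and phenyl in place of propyl at the same place gives a 1.1-fold lower number from compound 1 to compound 3 (0.05 log units; within the scatter), so neither exchange separates the compounds. The earlier pair showed only that two open chains of different length could not be told apart on this read-out; compound 3 extends this to a group of another kind, one six-membered aromatic ring of carbon only. All three compounds therefore stand level, and at this place neither chain length nor the exchange of a chain for this ring has yet moved the number beyond the scatter. For the compounds shown here, no evidence accompanying these compounds bears on this result.

The compounds shown leave open whether any group at this place can shift the number beyond the scatter, since all the groups here are hydrocarbons with no hydrogen-bond donors or acceptors. An amine or a carboxylic acid at the end of the chain, a much longer chain, or a phenyl carrying a methoxy group could each test this.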